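Trifluoromethyl for Methyl on the Urea Aryl Ring

A few compounds are considered here, and "the series" means these few. Any claim that something is new, unique, unknown or untested is made for them only; others in the source may bear on it.

Measured compounds:
Compound 1 `COc1cc2cc(Oc3ccc(NC(=O)Nc4ccccc4)cc3)c(C)nc2cc1OC` gives 42.8% in a functional assay on K562 cells (Homo sapiens) for inhibition, read by sulforhodamine B assay, with a stated time of 48 h, tested at 10 uM; a higher number here means a weaker effect of the compound at the concentration tested, a lower number a stronger effect.
Compound 2 `COc1cc2cc(Oc3ccc(NC(=O)Nc4ccc(C)cc4)cc3)c(C)nc2cc1OC` gives 90.8% in this assay.

Among the measured compounds shown here, compound 2 stands at the higher of the two numbers measured so far in this assay, and its nearest neighbour is compound 1, separated by the step of a number 48 percentage points higher from compound 1 to compound 2 (beyond the scatter). Compound 3 `COc1cc2cc(Oc3ccc(NC(=O)Nc4ccc(C(F)(F)F)cc4)cc3)c(C)nc2cc1OC` has not yet been measured. It differs from compound 2 by trifluoromethyl in place of methyl on an aromatic carbon.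

For the measured compounds named here, only one measured step bears on this change: the step of a number 48 percentage points higher from compound 1 to compound 2 (beyond the scatter), which was large and raised the number in this assay. Going by the values given here, it shows that a methyl in this place weakens the effect, but no measured pair tells how a trifluoromethyl in the same place compares with that methyl. Compound 3 is therefore expected to stay close to compound 2 in this assay, with the step of a number 8.8 percentage points lower from compound 2 to compound 3 (within the scatter), not clearly beyond the scatter in either direction. Compound 3 is estimated at 82%, within a range from 55% to 100%.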

Compound 3, a percentage reported as activity, at one concentration (the size of the read-out at that concentration, not a potency): 57.1%
Compound 3: middle estimate off by 24.9 percentage points, on the high side; low and high end bracket the measured number.
By their numbers in this assay, from the lowest: compound 1; then compound 3; then compound 2.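

In this assay the exchange of methyl for trifluoromethyl on this aromatic carbon is far from neutral: the record shows a number 33.7 percentage points lower from compound 2 to compound 3 (beyond the scatter) and thus a much stronger effect at the tested concentration. The outcome therefore depends on which group stands here, not merely on whether the hydrogen has been replaced. Even so, trifluoromethyl does not recover the full effect of the unsubstituted compound, as the record also shows a number 14.3 percentage points higher from compound 1 to compound 3 (beyond the scatter) for this change, so among these three compounds hydrogen gives the strongest effect, trifluoromethyl an intermediate one and methyl the weakest. No measurement available here accounts for this order of the three groups.

The compounds shown leave open where a different group on this carbon, such as methoxy, chlorine or an amine, would fall relative to hydrogen, trifluoromethyl and methyl. They also leave open whether the same order would hold with trifluoromethyl or methyl on another carbon of this ring, or at concentrations other than the single one tested.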